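Chain amine and aryl changes in a sigma ligand series

The source may report more compounds than this note shows. Statements on the series, on what has been measured and on what is new or still open speak of the compounds shown alone.

Compound 1, `CN(C)CCCCOc1ccc2oc(-c3ccccc3)cc(=O)c2c1`: 400 nM
Compound 2, `O=c1cc(-c2ccccc2)oc2ccc(OCCCCCCN3CCCCC3)cc12`: 54 nM
Compound 3, `CCOC(=O)C1CCN(CCCCCCOc2ccc3oc(-c4ccccc4)cc(=O)c3c2)CC1`: 102 nM

In an assay on isolated protein (Cavia porcellus) with Sigma non-opioid intracellular receptor 1 (Homo sapiens) as the target, read by radioligand binding (on this read-out lower numbers stand for stronger inhibition and higher numbers for weaker inhibition), compound 2 gives 54 nM, the lowest number of the three, though its gap to compound 3 stays within the scatter. Compound 3 gives 102 nM, and the step runs a 1.9-fold higher number from compound 2 to compound 3 (0.28 log units; within the scatter). Going by the values given here, compound 1 gives 400 nM, and the step runs a 7.4-fold lower number from compound 1 to compound 2 (0.87 log units; beyond the scatter), the only change in the set that clearly moves the number.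

Compound 4, `O=c1cc(-c2cccnc2)oc2ccc(OCCCCCCN3CCCCC3)cc12`, keeps the chain and amine of compound 2 and differs in one place: pyridin-3-yl in place of phenyl on an aromatic carbon. Neither measured step touches this part of the core; both concern the chain amine or a substituent on that ring. So no measured step bears directly on the change, and the shared core gives no guide to the size or direction of the effect. A step of modest size in either direction cannot be ruled out, and a number close to compound 2 is as plausible as a move beyond the scatter.

Compound 4 is therefore expected at 120 nM, with a range from 40 nM to 400 nM. The expected step is a 2.2-fold higher number from compound 2 to compound 4 (0.35 log units; beyond the scatter), a figure set wide for want of a comparable measured step.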

Compound 4, half-maximal inhibitory concentration: 192 nM
Compound 4: the middle estimate sits 1.6-fold (0.20 log units) below what was measured, and the stated range covers the measured number.
By their numbers in this assay, from the lowest: compounds 2, 3 and 4 (each within the scatter of the next, the first and the last beyond it); then compound 1.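

In this assay the aryl group on the aromatic carbon next to the ring oxygen proves to be a position that answers to change: pyridin-3-yl in place of phenyl gives a 3.6-fold higher number from compound 2 to compound 4 (0.55 log units; beyond the scatter) with the chain and amine held fixed. Up to this point the series had only steps at the chain amine and on a saturated ring carbon, so this is the first read on the aryl group itself. The two groups have the same count of heavy atoms, and the swap of one ring carbon for nitrogen adds one hydrogen-bond acceptor, which is enough to move the number in this assay, though nothing at hand speaks to why the number rises at this change.

This single pair cannot separate the presence of a ring nitrogen from its placement, and a pyridin-4-yl, pyrimidinyl or thienyl group at the same carbon would help to tell these apart. Also open is whether the step carries over to the other chain amines, such as the dimethylamino chain of compound 1 or the ethoxycarbonyl-bearing amine of compound 3, as no pair with pyridin-3-yl on those chains is shown.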